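Fluoro in Place of Methyl on the Aryl Ether

The source may report more compounds than this note shows. Statements on the series, on what has been measured and on what is new or still open speak of the compounds shown alone.

Compound 1 `Clc1ccccc1Oc1ncccc1C1CCNCC1` and compound 2 `COc1ccccc1Oc1ncccc1C1CCNCC1` share their core with compound 3 `Cc1ccc(Oc2ncccc2C2CCNCC2)c(F)c1` and differ from one another in a single substituent on the aryl ether. In an assay on HEK293 cells for displacement of a labelled ligand from sodium-dependent dopamine transporter (Homo sapiens), read by scintillation proximity assay (a higher number here means a weaker inhibitor, a lower number a stronger inhibitor), compound 1 gives 5150 nM, and compound 2 gives 6410 nM. Going by the values given here, the only complete step among the measured compounds is a 1.2-fold higher number from compound 1 to compound 2 (0.10 log units; within the scatter), a swap of one small aromatic substituent for another that left the number essentially where it was. Compound 3, in this assay, gives only a limit of > 6140 nM and not a number. That limit, (the limit of > 6140 nM in this assay, at which 1 of the 3 values shown sits), is where compound 3 stands, so its true value is known only to lie beyond it.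

Compound 4 `Fc1ccc(Oc2ncccc2C2CCNCC2)c(F)c1` differs from compound 3 by fluoro in place of methyl on an aromatic carbon. Among the compounds with values here, no measured step exchanges fluoro for methyl, and the one step that exists concerns other groups at another position, so it bears on this change only by showing that a small substituent swap on this ring gave a step within the scatter. Compound 4 is therefore expected to give about 9000 nM in this assay, within a range of 4000 nM to 25000 nM, with a real chance that only a limit is reported again. The estimated step that the limit leaves unreadable from compound 3 to compound 4 is expected to stay within the scatter.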

Compound 4, inhibition constant: 2590 nM
Beside the measured number, compound 4's estimate is 3.5-fold (0.54 log units) above it; the whole stated range lies above it.
By their numbers in this assay, from the lowest: compounds 4, 1 and 2 (each within the scatter of the next, the first and the last beyond it).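

Fluoro in place of methyl, meta to a fluoro group and para to a large group, is the one change on the aryl ether among those shown that moves the number in this assay beyond the scatter, with an at least 2.3-fold lower number from compound 3 to compound 4 (0.37 log units; beyond the scatter). The earlier step, a 1.2-fold higher number from compound 1 to compound 2 (0.10 log units; within the scatter), involved other groups at another place and stayed within the scatter, so it could not show that a single substituent swap on this ring can register at all; here, one heavy atom is exchanged for one heavy atom, with no hydrogen-bond donor, hydrogen-bond acceptor or net charge entering or leaving. The step has a floor and no known upper end because compound 3 is represented only by a limit: the limit of > 6140 nM in this assay, at which 1 of the 4 values shown sits.

Going by these compounds, whether the gain belongs to fluoro in particular stays open, since a single exchange cannot say how a chloro, trifluoromethyl, nitrile or methoxy group would read at this same place. Also open, on these data alone, is whether a longer chain or an amine there would carry the number further in this assay or return it toward the limit.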